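Sulfonamide series: methyl to methylamino on the core

A few compounds are considered here, and "the series" means these few. Any claim that something is new, unique, unknown or untested is made for them only; others in the source may bear on it.

Measured so far:
- compound 1 `O=S(=O)(Nc1ncnc2[nH]nc(O)c12)c1cccc(Cl)c1Cl` gives 15800 nM in a functional assay on cells for antagonist activity at C-C chemokine receptor type 4 (Homo sapiens), read by GTPgammaS binding; on this read-out lower numbers stand for stronger inhibition and higher numbers for weaker inhibition
- compound 2 `COc1nn(C)c2nc(C)nc(NS(=O)(=O)c3cccc(Cl)c3Cl)c12` gives 631 nM in this assay

Going by the values given here, compound 2 holds the lower of the two numbers; the only other value, that of compound 1, sits higher by a margin well beyond the scatter. The two differ in more than one place, so nothing is read from that gap beyond the two values themselves.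

Compound 3 `CNc1nc(NS(=O)(=O)c2cccc(Cl)c2Cl)c2c(OC)nn(C)c2n1` follows from compound 2 by a single change: methylamino in place of methyl on an aromatic carbon. Among the compounds with values here, no measured pair shows what a methyl to methylamino exchange at this place does. With nothing to anchor it, the step is expected to stay modest, near the scatter, with no clear direction. The expected step is a 1.3-fold lower number from compound 2 to compound 3 (0.10 log units; within the scatter). Compound 3 is estimated at 500 nM, within a range of 100 nM to 2500 nM.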

Compound 3, half-maximal inhibitory concentration: 79.4 nM
Beside the measured number, compound 3's estimate is 6.3-fold (0.80 log units) above it; measured number below the stated range.
By their numbers in this assay, from the lowest: compound 3; then compound 2; then compound 1.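

In this assay, going by these compounds alone, the aromatic carbon between two ring nitrogen atoms proves responsive to substitution, since methylamino in place of methyl gives a 7.9-fold lower number from compound 2 to compound 3 (0.90 log units; beyond the scatter) in the first single-place comparison of the series. The entering group brings one hydrogen-bond donor and one hydrogen-bond acceptor where the methyl counts none, but this one pair cannot show whether either of these goes with the lower number. No available evidence accounts for the size of the step.

The compounds shown leave open whether a plain amine, dimethylamino or a longer chain such as propylamino at this carbon would lower the number further or give it back. As far as these compounds go, whether the same exchange carries over to the core of compound 1 also remains open.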